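Swapping 3,4-dichlorophenyl for 4-bromophenyl: compound 3 to compound 4

The source may hold more compounds than are shown below. What is called first, only, known or untested is meant among the compounds shown, and "the series" means these compounds.

Compound 1 `CNC(=O)c1cc(Oc2ccc(C3=NNC(c4ccc(F)cc4Cl)C3)cc2)ccn1`: 13700 nM
Compound 2 `CNC(=O)c1cc(Oc2ccc(C3=NNC(c4cccc([N+](=O)[O-])c4)C3)cc2)ccn1`: "not determined" (no result reported)
Compound 3 `CNC(=O)c1cc(Oc2ccc(C3=NNC(c4ccc(Cl)c(Cl)c4)C3)cc2)ccn1`: 10700 nM

In a functional assay on A549 cells (Homo sapiens) for cytotoxicity, read by MTT assay, with a stated time of 72 h (on this read-out lower numbers stand for stronger inhibition and higher numbers for weaker inhibition), compound 3 gives 10700 nM. Only compound 1 offers a number to compare it with, and the two lie within the scatter of each other. Compound 2 adds nothing, since no result was reported for it.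

The next compound to be measured is compound 4 `CNC(=O)c1cc(Oc2ccc(C3=NNC(c4ccc(Br)cc4)C3)cc2)ccn1`. It differs from compound 3 as follows: 4-bromophenyl in place of 3,4-dichlorophenyl on a saturated ring carbon. In words, it has 4-bromophenyl in place of 3,4-dichlorophenyl on a saturated ring carbon, at the same place where compound 1 and compound 3 differ.

Among the compounds with values here, one measured step bears on this: a 1.3-fold lower number from compound 1 to compound 3 (0.11 log units; within the scatter), with 3,4-dichlorophenyl in place of 2-chloro-4-fluorophenyl. Within the data shown here, a single step is thin evidence, and no measured compound carries 4-bromophenyl. Even so, that step gives no reason to expect a shift beyond the scatter, in either direction.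

The expected size of the step is a 1.1-fold higher number from compound 3 to compound 4 (0.05 log units; within the scatter). In this assay the estimate for compound 4 is an expected 12000 nM, with an estimated range from 5500 nM to 26000 nM.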

Compound 4, half-maximal inhibitory concentration: 21000 nM
For compound 4 the middle estimate is 1.8-fold (0.24 log units) below the measured one, within the range that was stated.
By their numbers in this assay, from the lowest: compounds 3, 1 and 4 (each within the scatter of the next).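

In this assay, the place on the saturated ring carbon now holds a third halogen-bearing aryl group, and 4-bromophenyl gives a 2.0-fold higher number from compound 3 to compound 4 (0.29 log units; within the scatter) and also a 1.5-fold higher number from compound 1 to compound 4 (0.19 log units; within the scatter). Both steps lie within the scatter, so 4-bromophenyl, 3,4-dichlorophenyl and 2-chloro-4-fluorophenyl cannot be told apart at this position in this read-out, even though the halogens differ in kind and in number and the entering group has one heavy atom fewer than 3,4-dichlorophenyl. No evidence is at hand that bears on this result.

The compounds shown all carry a phenyl ring with halogen atoms at this place and have numbers in the same narrow band, so they leave open whether any other kind of group would move the number beyond the scatter, for example a phenyl ring bearing an amine or a carboxylic acid, or a longer alkyl chain in place of the ring. They also leave open whether the unsubstituted phenyl group would differ from these three, and whether the same lack of separation would hold on any cell line other than the one tested here.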